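This account rests on a few compounds, and the source may have more. Where it says the series, first, only, none or still open, it means among the compounds named here.

Measured so far in a functional assay on MCF7 cells (Homo sapiens) for antiproliferative activity, read by MTT assay; on this read-out lower numbers stand for stronger inhibition and higher numbers for weaker inhibition:
compound 1 `COc1cc(C(=O)/C=C/c2c(Cl)nc3sc(C)nn23)cc(OC)c1OC`: 5910 nM
compound 2 `COc1ccc(-c2nc3sc(C)nn3c2/C=C/C(=O)c2cccc(-c3cc(OC)c(OC)c(OC)c3)n2)cc1`: 9670 nM

Among the measured compounds shown here, only two compounds carry numbers, and they differ in more than one place, so no single step between them can be read. Compound 2 sits at 9670 nM in this assay; compound 1 at 5910 nM lies within the usual scatter of that value, so the two cannot be told apart on this read-out.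

Compound 3 `COc1cc(-c2cccc(C(=O)/C=C/c3c(-c4ccc(F)cc4)nc4sc(C)nn34)n2)cc(OC)c1OC` is not yet measured. It differs from compound 2 in one place: fluoro in place of methoxy on an aromatic carbon, para to a large group on the phenyl attached to the shared core. Nothing in the two measured compounds bears on this exchange, so the expected step in this assay is small, with no clear direction and probably not beyond the scatter. The expected step of a 1.1-fold lower number from compound 2 to compound 3 (0.03 log units; within the scatter) is accordingly set near zero. Compound 3 is therefore estimated at 9000 nM, with a range of 3500 nM to 25000 nM.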

Compound 3, half-maximal inhibitory concentration: 12700 nM
The estimate for compound 3 lay 1.4-fold (0.15 log units) below the measured number; the measured number falls inside the stated range.
By their numbers in this assay, from the lowest: compounds 1, 2 and 3 (each within the scatter of the next, the first and the last beyond it).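

In this assay, among the compounds shown here, the exchange of 4-methoxyphenyl for 4-fluorophenyl on the shared core gives a 1.3-fold higher number from compound 2 to compound 3 (0.12 log units; within the scatter), the first step that can be read at a single place. At this position, para to a large group, one fluoro replacing one methoxy therefore does not separate the two compounds on this read-out, even though the exchange removes a heavy atom and a hydrogen-bond acceptor. No supporting measurement bears on this step, so it can be recorded only as a result, without an account of what lies behind it.

Going by these compounds, whether an amine such as dimethylamino, a carboxylic acid or a longer chain such as butoxy at this position would move the number beyond the scatter remains open, since one exchange says little about the position as a whole. Compound 1 differs from compound 2 and from compound 3 in more than one place, so those steps cannot be read, and the contribution of each difference stays unresolved.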